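The compounds below may be only part of what the source reports. "The series", "measured", "known", "first", "only" and "open" are said of these compounds alone.

In an assay on CHO-K1 cells for displacement of a labelled ligand from adenosine receptor A1 (Homo sapiens), tested at 10 uM (on this read-out higher numbers stand for more inhibition at the one concentration tested (going by the name of the read-out) and lower numbers for less inhibition), compound 1 `CCOC(=O)c1c(-c2cccc(C(F)(F)F)c2)csc1N` gives 93% and compound 2 `CCOC(=O)c1c(N)sc(-c2ccccc2)c1-c1cccc(C(F)(F)F)c1` gives 83.6%. Compound 3 `CCOC(=O)c1c(N)sc(-c2ccc(C(C)=O)cc2)c1-c1cccc(C(F)(F)F)c1` gives 64.6% in this assay, the lowest of the three numbers: a number 19 percentage points lower from compound 2 to compound 3 (beyond the scatter) and a number 28.4 percentage points lower from compound 1 to compound 3 (beyond the scatter), whereas a number 9.4 percentage points lower from compound 1 to compound 2 (within the scatter). Compound 4 `CCOC(=O)c1c(N)sc(-c2ccc(Cl)cc2)c1-c1cccc(C(F)(F)F)c1` differs from compound 3 by chloro in place of acetyl on an aromatic carbon. Within the data shown here, the measured step that bears most directly is a number 19 percentage points lower from compound 2 to compound 3 (beyond the scatter), where the acetyl that now leaves had entered; no measured step shows chloro entering, so its own contribution stays unknown. The loss of the acetyl is expected to recover part of that drop in this assay, as a number 13.4 percentage points higher from compound 3 to compound 4 (beyond the scatter). Compound 4 is therefore estimated at 78% in this assay, within 60% to 92%.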

Compound 4, a percentage reported as inhibition, at one concentration (the size of the read-out at that concentration, not a potency): 58.4%
Compound 4: middle estimate off by 19.6 percentage points, on the high side; the measured number lies below the stated range.
By their numbers in this assay, from the lowest: compounds 4 and 3 (each within the scatter of the next); then compounds 2 and 1 (each within the scatter of the next).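

Chloro in place of acetyl on the 4-substituted phenyl brings no recovery in this assay (a number 6.2 percentage points lower from compound 3 to compound 4 (within the scatter)). The lower number therefore does not depend on acetyl alone: chloro in place of hydrogen also lies beyond the scatter (a number 25.2 percentage points lower from compound 2 to compound 4 (beyond the scatter)), as does the whole 4-chlorophenyl in place of hydrogen (a number 34.6 percentage points lower from compound 1 to compound 4 (beyond the scatter)).

On these data alone, whether an amine or a carboxylic acid at this place would stay closer to compound 2 remains open. No available evidence accounts for the loss with either group.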